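The compounds below may be only part of what the source reports. "The series", "measured", "known", "first", "only" and "open" are said of these compounds alone.

Compound 1 `CCCn1c(Br)nc2c(N)nc(NCc3ccccc3)nc21` and compound 2 `CCCn1c(-c2ccco2)nc2c(N)nc(NCc3ccccc3)nc21` share one core and differ in a single place. In an assay on CHO cells for displacement of a labelled ligand from transmembrane domain-containing protein TMIGD3 (Homo sapiens) (on this read-out lower numbers stand for stronger inhibition and higher numbers for weaker inhibition), compound 1 gives 650 nM, while compound 2 gives 29 nM; the change furan-2-yl in place of bromo on an aromatic carbon thus made a 22-fold lower number from compound 1 to compound 2 (1.35 log units; beyond the scatter). Compound 3 `CCCn1c(Br)nc2c(NCc3ccccc3)ncnc21` is built on a different core, and the difference between the two cores is not broken down here. In this assay compound 3 gives 11100 nM, the highest of the three numbers. Compound 4 `CCCn1c(-c2ccco2)nc2c(NCc3ccccc3)ncnc21` arises from compound 3 by the same change, (furan-2-yl in place of bromo on an aromatic carbon), at the same place. For compound 4 the expected step is a 16-fold lower number from compound 3 to compound 4 (1.20 log units; beyond the scatter), set somewhat smaller than the earlier one since it rests on a single earlier step of a 22-fold lower number from compound 1 to compound 2 (1.35 log units; beyond the scatter) seen on another core. For compound 4 the estimated value in this assay is 700 nM, with a likely range from 250 nM to 2500 nM.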

Compound 4, inhibition constant: 402 nM
For compound 4 the middle estimate is 1.7-fold (0.24 log units) above the measured one, and the stated range covers the measured number.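

In this assay, putting furan-2-yl in place of bromo gave a 28-fold lower number from compound 3 to compound 4 (1.44 log units; beyond the scatter), and this step matches the one seen earlier on the other core: the same change on two cores in this assay, a 22-fold lower number (1.35 log units; beyond the scatter) from compound 1 to compound 2 and a 28-fold lower number (1.44 log units; beyond the scatter) from compound 3 to compound 4, 1.2-fold (0.09 log units) apart, within the scatter of two such steps. So in this small set, the change carried from one core to the other with its size kept. This rests on two cores only; it does not show that the step would hold on a third core, and it does not explain why the two steps match.

As far as these compounds go, it remains open whether another group at this place, such as a phenyl ring, a thiophene or a simple methyl, would give a similar step. From the compounds shown here alone, it is also open whether the step would survive if a longer chain replaced the propyl group.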